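Swapping the nitrophenyl acyl group for a trifluoromethylphenyl

The source may hold more compounds than are shown below. What is called first, only, known or untested is meant among the compounds shown, and "the series" means these compounds.

Three analogues of one shared core have been tested in a functional assay on BCG823 cells (Homo sapiens) for inhibition, read by MTT assay, with a stated time of 72 h; on this read-out lower numbers stand for stronger inhibition and higher numbers for weaker inhibition. Compound 1 `CN(C(=O)NC(=O)c1ccc(Cl)cc1Cl)c1nc(C(F)(F)F)c(C(=O)N/N=C/c2cccc(C(F)(F)F)c2)s1` gives 6.11 ug/mL, compound 2 `CN(C(=O)NC(=O)c1cccc(C(F)(F)F)c1)c1nc(C(F)(F)F)c(C(=O)N/N=C/c2cc(C(F)(F)F)cc(C(F)(F)F)c2)s1` gives 5.23 ug/mL, and compound 3 `CN(C(=O)NC(=O)c1ccc([N+](=O)[O-])cc1)c1nc(C(F)(F)F)c(C(=O)N/N=C/c2cccc(C(F)(F)F)c2)s1` gives 1.67 ug/mL, the lowest of the three numbers, with compound 2 closest and compound 1 furthest. For the measured compounds named here, the single step characterised so far, a 3.7-fold lower number from compound 1 to compound 3 (0.56 log units; beyond the scatter), shows the nitrophenyl group in this position favouring inhibition. Compound 4 `CN(C(=O)NC(=O)c1cccc(C(F)(F)F)c1)c1nc(C(F)(F)F)c(C(=O)N/N=C/c2cccc(C(F)(F)F)c2)s1` differs from compound 3 by 3-(trifluoromethyl)phenyl in place of 4-nitrophenyl on a carbonyl carbon, undoing that change in another direction; compound 2, which carries the same acyl group but a different hydrazone, gives 5.23 ug/mL. Compound 4 is therefore expected to show a higher number, a step of about a 2.7-fold higher number from compound 3 to compound 4 (0.43 log units; beyond the scatter), with an estimate of 4.5 ug/mL and a range from 2 ug/mL to 10 ug/mL.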

Compound 4, half-maximal inhibitory concentration: 4.6 ug/mL
Compound 4: middle estimate off by 1.0-fold (0.01 log units), on the low side, within the range that was stated.
By their numbers in this assay, from the lowest: compound 3; then compounds 4, 2 and 1 (each within the scatter of the next).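

In this assay the change to 3-(trifluoromethyl)phenyl gives a 2.8-fold higher number from compound 3 to compound 4 (0.44 log units; beyond the scatter) and so sets a second acyl group apart from 4-nitrophenyl on this carbonyl carbon. That group and 2,4-dichlorophenyl cannot be told apart, with a 1.3-fold lower number from compound 1 to compound 4 (0.12 log units; within the scatter) as their step, and hydrogen in place of trifluoromethyl on an aromatic carbon gives a 1.1-fold lower number from compound 2 to compound 4 (0.06 log units; within the scatter) and likewise stays within the scatter. Nothing available explains why 4-nitrophenyl stands apart. Still open, going by these compounds, is whether an amine or a carboxylic acid in place of the nitro group would keep the lower number.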